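Phenyl in Place of Methyl on an Amine Nitrogen in a Ring

A few compounds are considered here, and "the series" means these few. Any claim that something is new, unique, unknown or untested is made for them only; others in the source may bear on it.

Compound 1 `CCOCCn1c(N2CCN(C)CC2)nc2ccccc21`: 10 nM
Compound 2 `COCCn1c(N2CCN(C)CC2)nc2ccccc21`: 13 nM

In a functional assay on ileum for inhibition of histamine H1 receptor (Cavia porcellus) (on this read-out higher numbers stand for weaker inhibition and lower numbers for stronger inhibition), compound 1 gives the lowest of the two numbers shown, and compound 2 lies a 1.3-fold higher number from compound 1 to compound 2 (0.11 log units; within the scatter) from it. Compound 3 `CCOCCn1c(N2CCN(c3ccccc3)CC2)nc2ccccc21` differs from compound 1 in one place: phenyl in place of methyl on an amine nitrogen in a ring. Within the data shown here, the only measured step touches the saturated chain, not the amine nitrogen in a ring, so no measured step bears on this change and its size is open. Compound 3 is nevertheless expected to sit at a higher number, a step of a 15-fold higher number from compound 1 to compound 3 (1.18 log units; beyond the scatter). Compound 3 is estimated at 150 nM, between 20 nM and 1500 nM.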

Compound 3, half-maximal inhibitory concentration: > 10000 nM
Compound 3 gave a limit, no number; the forecaster's own chance of this, stated with the estimate: 5%; middle value at least 66-fold (1.82 log units) from the limit.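

At the amine nitrogen in a ring, phenyl in place of methyl is a large change in this assay (an at least 1000-fold higher number from compound 1 to compound 3 (3.00 log units; beyond the scatter)). Among these compounds, the only earlier step, on the saturated chain, stayed within the scatter (a 1.3-fold higher number from compound 1 to compound 2 (0.11 log units; within the scatter)), so this is the first sign that the result depends on the group at this nitrogen. The result for compound 3 is a limit of the assay, not a number: the limit of > 10000 nM in this assay, at which 1 of the 3 values shown sits.

The compounds shown leave open whether ethyl or hydrogen at this nitrogen would keep the low number of compound 1. They also leave open whether benzyl would behave like phenyl or like methyl.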